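From Methyl to Methoxyphenyl on a Sulfonyl Sulfur

A few compounds are considered here, and "the series" means these few. Any claim that something is new, unique, unknown or untested is made for them only; others in the source may bear on it.

Among the compounds with values here, compound 1 `CS(=O)(=O)Nc1ccc(-c2nc3ccccc3o2)cc1` is one of two compounds so far tested in an assay on isolated protein for inhibition of malate dehydrogenase, mitochondrial (Sus scrofa), with stated times of 45 min and 30 min; a higher number here means a weaker inhibitor, a lower number a stronger inhibitor. In this assay compound 1 gives > 63000 nM, a limit of the assay rather than a number. Compound 2 `O=[N+]([O-])c1cc(S(=O)(=O)Nc2ccc(-c3nc4ccccc4o3)cc2)ccc1Cl` carries a larger substituent on the sulfonyl sulfur. In this assay compound 2 gives > 63000 nM, again a limit rather than a number. Together the two values show only that neither compound reached measurable inhibition, both standing at the limit of > 63000 nM in this assay, at which 2 of the 2 values shown sit. Compound 3 `COc1ccc(S(=O)(=O)Nc2ccc(-c3nc4ccccc4o3)cc2)cc1` has not been measured. It differs from compound 1 by 4-methoxyphenyl in place of methyl on a sulfonyl sulfur. Within the data shown here, no step between measured compounds is on record, so the step can only be expected: the estimate implies a step that the limit leaves unreadable from compound 1 to compound 3, which is expected to stay within the usual scatter. For compound 3 the expected value in this assay is 80000 nM, with a range from 30000 nM to 250000 nM, most probably reported again only as a limit.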

Compound 3, half-maximal inhibitory concentration: > 63000 nM
Compound 3 gave a limit, no number; the forecaster's own chance of this, stated with the estimate: 75%; the middle value lies beyond the limit too.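

Within the data shown here, compound 1 and compound 3 both stand at a limit, so no step from methyl to 4-methoxyphenyl on the sulfonyl sulfur can be read: the limit of > 63000 nM in this assay, at which 3 of the 3 values shown sit. The compounds shown leave open whether any group at that place gives a measurable number in this assay.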